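This account rests on a few compounds, and the source may have more. Where it says the series, first, only, none or still open, it means among the compounds named here.

Compound 1 `CCOC(=O)C1=C(C)N/C(=C/c2cc(C)n(-c3ccc(CN(C)C)cc3)c2C)C1=O`: 120000 nM
Compound 2 `CCOC(=O)C1=C(C)N/C(=C/c2cc(C)n(-c3ccc([S+](C)[O-])cc3)c2C)C1=O`: 220000 nM
Compound 3 `CCOC(=O)C1=C(C)N/C(=C/c2cc(C)n(-c3ccc(SC)cc3)c2C)C1=O`: 54000 nM

In an ADME assay on L6 cells (Rattus norvegicus) for cytotoxicity, read by resazurin assay, with a stated time of 72 h (a lower number here means that less compound is needed, a higher number that more compound is needed for the effect), compound 3 gives 54000 nM and stands lowest of the three, as the steps of a 2.2-fold lower number from compound 1 to compound 3 (0.35 log units; beyond the scatter) and a 4.1-fold lower number from compound 2 to compound 3 (0.61 log units; beyond the scatter) show. Compound 4 `CCOC(=O)C1=C(C)N/C(=C/c2cc(C)n(Cc3ccccc3)c2C)C1=O` differs from compound 3 by benzyl in place of 4-(methylsulfanyl)phenyl on an aromatic nitrogen. Going by the values given here, no measured step changes a group on that aromatic nitrogen; every measured step swaps a small group on an aromatic carbon of the phenyl ring, and even the largest, a 4.1-fold lower number from compound 2 to compound 3 (0.61 log units; beyond the scatter), is only modest. The whole phenyl ring is now replaced, so the measured steps give only a weak guide, and a modest step in either direction, or none beyond the scatter, is expected. Compound 4 is therefore estimated at 80000 nM, within 30000 nM to 220000 nM, an expected step of a 1.5-fold higher number from compound 3 to compound 4 (0.17 log units; within the scatter).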

Compound 4, half-maximal effective concentration: 50000 nM
The estimate for compound 4 lay 1.6-fold (0.20 log units) above the measured number; low and high end bracket the measured number.
By their numbers in this assay, from the lowest: compounds 4 and 3 (each within the scatter of the next); then compounds 1 and 2 (each within the scatter of the next).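

In this assay, the whole 4-(methylsulfanyl)phenyl on the aromatic nitrogen gives way to benzyl, which has a different link to the ring and no sulfur, with no shift beyond the scatter: a 1.1-fold lower number from compound 3 to compound 4 (0.03 log units; within the scatter). The other two steps, a 4.4-fold lower number from compound 2 to compound 4 (0.64 log units; beyond the scatter) and a 2.4-fold lower number from compound 1 to compound 4 (0.38 log units; beyond the scatter), are both modest, so at this position, among these four compounds, the numbers stay in a narrow range even when the group is replaced outright. Nothing available explains this result.

Still open, from the compounds shown here alone, is how a longer chain, such as phenylethyl, would behave on that nitrogen. Also open, going by these compounds, is what an amine or a carboxylic acid on the benzyl ring would do.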